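A few compounds are considered here, and "the series" means these few. Any claim that something is new, unique, unknown or untested is made for them only; others in the source may bear on it.

Measured so far in a functional assay on SMMC-7721 cells (Homo sapiens) for cytotoxicity, read by MTT assay, with a stated time of 24 h; a higher number here means a weaker inhibitor, a lower number a stronger inhibitor:
- compound 1 `O=C1/C(=C/c2ccccc2F)CN(S(=O)(=O)c2ccc(O[N+](=O)[O-])cc2)C/C1=C\c1ccccc1F`: 6200 nM
- compound 2 `O=C1/C(=C/c2ccccc2F)CN(S(=O)(=O)c2ccc(Br)cc2)C/C1=C\c1ccccc1F`: 5200 nM

Going by the values given here, compound 2 has the lower of the two numbers in this assay, though the single measured step, a 1.2-fold lower number from compound 1 to compound 2 (0.08 log units; within the scatter), is within the scatter, so the two compounds cannot be ordered. Compound 3 `CC(=O)Nc1ccc(S(=O)(=O)N2C/C(=C\c3ccccc3F)C(=O)/C(=C/c3ccccc3F)C2)cc1` differs from compound 2 by acetamido in place of bromo on an aromatic carbon. Among the compounds with values here, no measured step involves an acetamido group, and the one step available changes a different substituent at the same place without effect beyond the scatter. Compound 3 is therefore expected to show no step beyond the scatter, a 1.2-fold higher number from compound 2 to compound 3 (0.06 log units; within the scatter). The estimate for compound 3 is 6000 nM, with a range of 2500 nM to 15000 nM.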

Compound 3, half-maximal inhibitory concentration: 7500 nM
The estimate for compound 3 lay 1.3-fold (0.10 log units) below the measured number; the measured number falls inside the stated range.
By their numbers in this assay, from the lowest: compounds 2, 1 and 3 (each within the scatter of the next).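

Acetamido in place of bromo gives a 1.4-fold higher number from compound 2 to compound 3 (0.16 log units; within the scatter) and acetamido in place of nitrooxy gives a 1.2-fold higher number from compound 1 to compound 3 (0.08 log units; within the scatter) in this assay at this place, on an aromatic carbon para to a large group. The series now has a substituent with a hydrogen-bond donor at this place, and the three groups remain within the scatter of one another.

As far as these compounds go, whether an amine, a carboxylic acid or a longer chain at this place would give a step beyond the scatter remains open. No evidence bears on the reason for these numbers.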